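Swapping the ring on nitrogen: compound 1 to compound 4

The compounds below may be only part of what the source reports. "The series", "measured", "known", "first", "only" and "open" are said of these compounds alone.

Compound 1 `CCc1ccc(-n2nc(-c3ccc(C(F)(F)F)cc3O)nc2-c2ccccc2O)cc1` stands highest of the three numbers in a functional assay on PC-12 cells (Rattus norvegicus) for cytotoxicity, read by MTT assay, with stated times of 2 h and 24 h, tested at 10 uM (a lower number here means a weaker effect, a higher number a stronger effect of the compound at the concentration tested), where compound 1 gives 107%. Compound 3 `Oc1cc(C(F)(F)F)ccc1-c1nc(-c2ccccc2O)n(-c2ccc(F)cc2)n1` lies nearest, as compound 3 gives 99.8%. Compound 2 `CC(C)(C)c1ccc(-n2nc(-c3ccc(C(F)(F)F)cc3O)nc2-c2ccccc2O)cc1` lies furthest, as compound 2 gives 81.1%.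

Compound 4 `Oc1cc(C(F)(F)F)ccc1-c1nc(-c2ccccc2O)n(-c2ccccc2Cl)n1` differs from compound 1 in one place: 2-chlorophenyl in place of 4-ethylphenyl on an aromatic nitrogen. Among the compounds with values here, two measured steps bear on this change, both altering the group carried on the same ring of compound 1. With tert-butyl in place of ethyl there was a number 25.9 percentage points lower from compound 1 to compound 2 (beyond the scatter), a modest drop, while with fluoro in place of ethyl there was a number 7.2 percentage points lower from compound 1 to compound 3 (within the scatter), within the scatter; between those two compounds, a number 18.7 percentage points higher from compound 2 to compound 3 (beyond the scatter). Since the change to compound 4 exchanges the whole ring rather than one group on it, and the measured steps range from none to modest, the account expects at most a modest step in this assay, more likely downward than upward. For compound 4 the estimate is 98%, between 80% and 114%, which means an expected step of a number 9 percentage points lower from compound 1 to compound 4 (within the scatter).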

Compound 4, a percentage reported as activity, at one concentration (the size of the read-out at that concentration, not a potency): 102%
Compound 4: middle estimate off by 4 percentage points, on the low side, within the range that was stated.
By their numbers in this assay, from the lowest: compound 2; then compounds 3, 4 and 1 (each within the scatter of the next).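

In this assay, within the data shown here, this is the first change of the whole ring on the aromatic nitrogen, and it moves the substituent as well as altering it. Exchanging 4-ethylphenyl for 2-chlorophenyl gives a number 5 percentage points lower from compound 1 to compound 4 (within the scatter) and exchanging 4-fluorophenyl gives a number 2.2 percentage points higher from compound 3 to compound 4 (within the scatter) while exchanging 4-(tert-butyl)phenyl gives a number 20.9 percentage points higher from compound 2 to compound 4 (beyond the scatter) so that among these four compounds, only compound 2 stands apart, as the lowest. Nothing measured here explains why these ring changes differ in their effect.

The compounds shown leave open whether 4-chlorophenyl would match compound 4, which would separate the effect of chlorine from that of its place on the ring. They also leave open how an amine, a carboxylic acid or a chain longer than ethyl on this ring would read.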